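The source may hold more compounds than are shown below. What is called first, only, known or untested is meant among the compounds shown, and "the series" means these compounds.

Measured so far in a functional assay on A549 cells (Homo sapiens), read by MTT assay, with a stated time of 72 h; a higher number here means a weaker inhibitor, a lower number a stronger inhibitor:

compound 1 `Nc1nc2c(c(-c3ccccc3)cn2[C@@H]2O[C@H](CO)[C@@H](O)[C@H]2O)c(=O)[nH]1`: > 100000 nM
compound 2 `O=c1[nH]cnc2c1c(-c1ccsc1)cn2[C@@H]1O[C@H](CO)[C@@H](O)[C@H]1O`: > 20000 nM
compound 3 `Nc1nc2c(c(-c3ccco3)cn2[C@@H]2O[C@H](CO)[C@@H](O)[C@H]2O)c(=O)[nH]1`: > 20000 nM

Compound 1 gives only a limit of this assay, not a number. Compound 2 likewise reaches only a limit of this assay. Compound 3 too is reported only as a limit of this assay. Compound 3 therefore stands nowhere that can be read against the others: all three measured compounds sit at limits, as the limit of > 100000 nM in this assay, at which 1 of the 3 values shown sits, and the limit of > 20000 nM in this assay, at which 2 of the 3 values shown sit, show, and the step that the two limits leave unreadable from compound 1 to compound 3 cannot be read as a size.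

Compound 4 `Nc1nc2c(c(-c3ccsc3)cn2[C@@H]2O[C@H](CO)[C@@H](O)[C@H]2O)c(=O)[nH]1` has not yet been measured. It differs from compound 3 in one place: thiophen-3-yl in place of furan-2-yl on an aromatic carbon. Within the data shown here, no measured step bears readably on this change; the only measured step with a related ring exchange is unreadable, and compound 2, which carries the same thiophen-3-yl group on a core lacking the amino group, also sits at a limit. The step that the limit leaves unreadable from compound 3 to compound 4 is thus expected to be none beyond the scatter, with compound 4 most likely again reported as a limit. The estimate for compound 4 in this assay is 50000 nM, with a range from 20000 nM to 200000 nM.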

Compound 4, half-maximal inhibitory concentration: > 20000 nM
Compound 4: only a limit was reported; the forecaster's own chance of this, stated with the estimate: 85%; the middle value does not contradict the limit.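

Compound 4, like compound 1, compound 2 and compound 3, is reported only as a limit in this assay, so none of its steps to those compounds can be read. The compounds shown leave open whether any of these changes on the shared core alters the true value in this assay.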